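Methoxy to hydroxy change carried onto a second core

This account rests on a few compounds, and the source may have more. Where it says the series, first, only, none or still open, it means among the compounds named here.

Compound 2 `COc1cc(-c2nn(-c3cccc(NC(=O)Nc4cccc(C(F)(F)F)c4)c3)cc2-c2ccncc2)ccc1Cl` carries a 4-chloro-3-methoxyphenyl group; in a functional assay on UO-31 cells (Homo sapiens) for inhibition, read by sulforhodamine B assay, with a stated time of 48 h (on this read-out higher numbers stand for weaker inhibition of growth and lower numbers for stronger inhibition of growth), compound 2 gives 3210 nM. Compound 1 `O=C(Nc1cccc(-n2cc(-c3ccncc3)c(-c3ccc(Cl)c(O)c3)n2)c1)Nc1cccc(C(F)(F)F)c1` differs from compound 2 by hydrogen in place of methyl on an oxygen on an aromatic ring. In this assay compound 1 reaches only > 32500 nM, which is a limit of the assay and not a number (the limit of > 32500 nM in this assay, at which 1 of the 3 values shown sits). The step of an at least 10-fold higher number from compound 2 to compound 1 (1.00 log units; beyond the scatter) is accordingly read as a lower bound on the loss. Compound 3 `COc1cc(-c2nn(-c3cccc(NC(=O)Nc4ccc(Cl)c(C(F)(F)F)c4)c3)cc2-c2ccncc2)ccc1Cl` differs from compound 2 by chloro in place of hydrogen on an aromatic carbon; in this assay compound 3 gives 4100 nM, and the step of a 1.3-fold higher number from compound 2 to compound 3 (0.11 log units; within the scatter) leaves the two values within the scatter.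

Compound 4 `O=C(Nc1cccc(-n2cc(-c3ccncc3)c(-c3ccc(Cl)c(O)c3)n2)c1)Nc1ccc(Cl)c(C(F)(F)F)c1` is not yet measured; it differs from compound 3 by hydrogen in place of methyl on an oxygen on an aromatic ring. The place of this change is the same, word for word, as the place of the change from compound 2 to compound 1, so it is the same change made on the core of compound 3. With the two cores lying within the scatter of each other by a 1.3-fold higher number from compound 2 to compound 3 (0.11 log units; within the scatter), a loss of the same size is expected on the second core as on the first. For compound 4 the step of an 11-fold higher number from compound 3 to compound 4 (1.04 log units; beyond the scatter) is expected, resting on an at least 10-fold higher number from compound 2 to compound 1 (1.00 log units; beyond the scatter). Compound 4 is estimated at 45000 nM in this assay, with a range from 15000 nM to 150000 nM, and it is expected that the assay will most likely again return only a limit.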

Compound 4, concentration for total growth inhibition: 3010 nM
Compound 4: middle estimate off by 15-fold (1.17 log units), on the high side; measured number below the stated range.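

The methoxy to hydroxy change does not carry over unchanged from one core to the other in this assay: on the core of compound 3, replacing 4-chloro-3-methoxyphenyl with 4-chloro-3-hydroxyphenyl gives a 1.4-fold lower number from compound 3 to compound 4 (0.13 log units; within the scatter), and this differs from the step on the core of compound 2: the same change on two cores in this assay, an at least 10-fold higher number (1.00 log units; beyond the scatter) from compound 2 to compound 1 and a 1.4-fold lower number (0.13 log units; within the scatter) from compound 3 to compound 4, at least 13-fold (1.13 log units) apart, beyond the scatter of two such steps

Read along the other change, chloro in place of hydrogen on an aromatic carbon has no effect beyond the scatter among the methoxy compounds, but on the hydroxy compounds it gives an at least 10-fold lower number from compound 1 to compound 4 (1.03 log units; beyond the scatter), so the effect of each change depends on the other in this set: the same change on two cores in this assay, a 1.3-fold higher number (0.11 log units; within the scatter) from compound 2 to compound 3 and an at least 10-fold lower number (1.03 log units; beyond the scatter) from compound 1 to compound 4, at least 13-fold (1.13 log units) apart, beyond the scatter of two such steps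

Compound 1 gives > 32500 nM, a limit of the assay and not a number, so every step touching it is a bound, and these four compounds give neither a cause for the difference nor a rule for other cores.

Still open, as far as these compounds go, is whether the hydroxy compound keeps its value when the added chloro of compound 4 gives way to a fluoro or a methyl. Also open, from the compounds shown here alone, is whether an ethoxy or an amine in place of the hydroxy follows compound 1 or compound 4.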